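The source may report more compounds than this note shows. Statements on the series, on what has been measured and on what is new or still open speak of the compounds shown alone.

Four compounds share one core, and only one of them has a number. For compound 1 `Cc1nc(-c2ccc(N3C(=O)C(O)=C(C(=O)C(C)(C)C)C3c3ccccc3OCCO)cc2)no1` the entry in an ADME assay on the whole organism (Rattus norvegicus) for pharmacokinetics (a lower number here means slower removal, a higher number faster removal of the compound), reads "not determined" (no result reported), and for compound 2 `Cc1noc(-c2ccc(N3C(=O)C(O)=C(C(=O)C(C)(C)C)C3c3ccccc3OCCO)cc2)n1` the entry in this assay reads "not determined" (no result reported), so neither can be placed. For the measured compounds named here, compound 3 `CC(C)(C)C(=O)C1=C(O)C(=O)N(c2ccc(-c3ccsc3)cc2)C1c1ccccc1OCCO` is the one that was measured: in this assay compound 3 gives 0.5 mL/min/kg, the only number in the set, so it stands alone, with nothing beside it to rank it against, and with no pair of measured compounds that differ in one place there is no step to read off either.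

Compound 4 `CC(C)(C)C(=O)C1=C(O)C(=O)N(c2ccc(-c3cccs3)cc2)C1c1ccccc1OCCO` is the next compound and differs from compound 3 in a single respect: thiophen-2-yl in place of thiophen-3-yl on an aromatic carbon. The two structures hold the same atoms joined differently, and the exchanged group sits para to a large group on the six-membered ring of carbon only.

Going by the values given here, with no measured step to lean on, the expectation rests on the size of the change alone. The step from compound 3 to compound 4 in this assay is estimated at a 1.2-fold higher number from compound 3 to compound 4 (0.08 log units; within the scatter), which is no step beyond the usual scatter in either direction. In this assay compound 4 is therefore expected to give about 0.6 mL/min/kg, with a range from 0.25 mL/min/kg to 1.5 mL/min/kg.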

Compound 4, clearance: 1.3 mL/min/kg
Estimate against measurement, compound 4: 2.2-fold (0.34 log units) below; the range from low to high includes it.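

Moving the bond from the 3-carbon to the 2-carbon of the thiophene gives, in this assay, a 2.6-fold higher number from compound 3 to compound 4 (0.41 log units; beyond the scatter), the first measured step in this set and a modest one. It shows that this position, on an aromatic carbon para to a large group, is not indifferent to a change that keeps the same atoms and leaves the counts of hydrogen-bond donors and acceptors in the exchanged group the same, so the way the thiophene is joined matters on its own in the whole animal. Nothing available explains why the step takes this direction or this size.

Compound 1 and compound 2 carry no number, so any steps between them and the two thiophene compounds cannot be read. Also open, from the compounds shown here alone, is how a group such as an amine, a carboxylic acid or a plain phenyl at this same position would stand in this assay, and whether the change from thiophen-3-yl to thiophen-2-yl would give a similar step with other groups elsewhere on the shared core.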